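Compound 3 to compound 4: exchanging the side chain

A few compounds are considered here, and "the series" means these few. Any claim that something is new, unique, unknown or untested is made for them only; others in the source may bear on it.

Values measured in a physicochemical assay for solubility, in phosphate buffer, at pH 7.2 (a higher number here means a more soluble compound, a lower number a less soluble compound), are these:
- Compound 1 `COc1cc(C2CN(C(=O)c3cc(OC[C@H](O)CO)ccn3)C2)ccc1OCc1ccc(C2CC2)cc1` gives 2700 nM
- Compound 2 `COc1cc(C2CN(C(=O)c3cc(OCCCC(=O)O)ccn3)C2)ccc1OCc1ccc(C2CC2)cc1` gives 1100 nM
- Compound 3 `COc1cc(C2CN(C(=O)c3cc(OCCCC(C)(C)C(=O)O)ccn3)C2)ccc1OCc1ccc(C2CC2)cc1` gives 11400 nM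

Of the three, compound 3 stands highest, beyond the scatter of both others. Compound 4 `COc1cc(C2CN(C(=O)c3cc(COC[C@H](O)CO)ccn3)C2)ccc1OCc1ccc(C2CC2)cc1` has (2,3-dihydroxypropoxy)methyl in place of (4-carboxy-4-methylpentyl)oxy on an aromatic carbon and remains unmeasured. The measured steps bearing on it are a 4.2-fold higher number from compound 1 to compound 3 (0.63 log units; beyond the scatter) and a 2.5-fold lower number from compound 1 to compound 2 (0.39 log units; beyond the scatter) (both modest) and a 10-fold higher number from compound 2 to compound 3 (1.02 log units; beyond the scatter) (large). Compound 4 shares 1,2-dihydroxyethyl with compound 1 (2700 nM) so a modest step to a lower number in this assay is expected. The estimated step is a 4.6-fold lower number from compound 3 to compound 4 (0.66 log units; beyond the scatter) (a modest one). The expected value for compound 4 is 2500 nM (range 900 nM to 7000 nM).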

Compound 4, solubility: 6700 nM
Compound 4: middle estimate off by 2.7-fold (0.43 log units), on the low side; the range from low to high includes it.
By their numbers in this assay, from the lowest: compound 2; then compound 1; then compounds 4 and 3 (each within the scatter of the next).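

In this assay, placing (2,3-dihydroxypropoxy)methyl on the aromatic carbon where compound 1 carries 2,3-dihydroxypropoxy gives a 2.5-fold higher number from compound 1 to compound 4 (0.39 log units; beyond the scatter) and so shows that this position responds to a change in the link alone, with the diol end kept. The same group gives a 6.1-fold higher number from compound 2 to compound 4 (0.78 log units; beyond the scatter) and, against (4-carboxy-4-methylpentyl)oxy, a 1.7-fold lower number from compound 3 to compound 4 (0.23 log units; within the scatter) so that the side chains of these two compounds cannot be separated here. Nothing available explains these differences.

From the compounds shown here alone, whether an amine at the end of this chain, or a longer chain bearing the diol, would keep the number at this level remains open.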